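The compounds below may be only part of what the source reports. "The series", "measured", "known", "first", "only" and "open" are said of these compounds alone.

Working notes on a short series built on one shared core. Among the compounds with values here, compound 1 `CCCCCCCCCCCCCCCOC1(c2ccc(Cl)cc2)SC=C(C)n2c1noc2=O` is the first entry; in a functional assay on A2780/DX3 cells (Homo sapiens) for antiproliferative activity, read by MTT assay, with a stated time of 3 days (a lower number here means a stronger inhibitor, a higher number a weaker inhibitor), compound 1 gives > 100000 nM, which is a limit of the assay and not a number. Compound 3 `CCCCCCCCCCCCCCCCCCOC1(c2ccc(Cl)cc2)SC=C(C)n2c1noc2=O` differs from compound 1 only by hydrogen in place of propyl on a saturated chain carbon, ten or more bonds along the chain from an oxygen on a saturated carbon. In this assay compound 3 gives > 100000 nM, again a limit rather than a number. Within the data shown here, compound 2 `CCCCOC1(c2ccc(Cl)cc2)SC=C(C)n2c1noc2=O` carries the butoxy group; in this assay compound 2 gives 49000 nM, the only numerical value in the set so far. Because of the limit of > 100000 nM in this assay, at which 2 of the 3 values shown sit, the step that the two limits leave unreadable from compound 3 to compound 1 cannot be sized. The step of an at least 2.0-fold lower number from compound 1 to compound 2 (0.30 log units; that floor lies within the scatter) reads lower for the shorter chain, but its floor lies within the scatter, so little weight rests on it.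

Compound 4 `COC1(c2ccc(Cl)cc2)SC=C(C)n2c1noc2=O` is not yet measured. It differs from compound 2 by hydrogen in place of propyl on a saturated chain carbon bound to an oxygen on a saturated carbon. Among the measured compounds shown here, this is the same kind of change as the one from compound 3 to compound 1, though not at the same place on the chain, as the two descriptions of the changes show. The difference between compound 2 and compound 3 is not broken down here.

Expectation: the earlier step of this kind gave no readable size, and the only numerical anchor is compound 2 at 49000 nM. The step from compound 2 to compound 4 is therefore expected to be small, about a 1.1-fold lower number from compound 2 to compound 4 (0.04 log units; within the scatter). Compound 4 is estimated at 45000 nM in this assay, with a likely range of 12000 nM to 100000 nM.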

Compound 4, half-maximal inhibitory concentration: 113000 nM
The estimate for compound 4 lay 2.5-fold (0.40 log units) below the measured number, outside the stated range (above it).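

In this assay, the change from butoxy to methoxy, hydrogen in place of propyl on a saturated chain carbon bound to an oxygen on a saturated carbon, gives a 2.3-fold higher number from compound 2 to compound 4 (0.36 log units; beyond the scatter), so on the shared core this change at this place on the chain is a readable step and raises the number. That is a single readable case at one place on the chain, and every compound shown carries the same core, so it shows neither that the step keeps its size or direction on another core nor that it holds further out along the chain. The same kind of change from compound 3 to compound 1 offers no second case, and the steps with no readable size stay unread, because of this: the limit of > 100000 nM in this assay, at which 2 of the 4 values shown sit.

The compounds shown leave open how the number runs between methoxy and butoxy and beyond butoxy, for instance with an ethoxy or a hexyloxy group, where a chain of that kind might still give a number rather than a limit. They also leave open whether a chain ending in an amine or a carboxylic acid would read differently from the plain chains here.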